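Lipophilicity notes on acylated amino-acid nucleoside amides

A few compounds are considered here, and "the series" means these few. Any claim that something is new, unique, unknown or untested is made for them only; others in the source may bear on it.

Measured so far:
compound 1 `CCCCCCCCCCCCCCCCCC(=O)N[C@@H](CCSC)C(=O)Nc1ccn([C@H]2O[C@@H](CO)[C@H](O)[C@H]2O)c(=O)n1` gives 1.09 in a physicochemical assay for lipophilicity; on this read-out lower numbers stand for lower lipophilicity and higher numbers for higher lipophilicity
compound 2 `CCCCCCCCCCCCCCCCCC(=O)N[C@@H](CCC(=O)O)C(=O)Nc1ccn([C@H]2O[C@@H](CO)[C@H](O)[C@H]2O)c(=O)n1` gives 0.5 in this assay
compound 3 `CCCCCCCCCC(=O)N[C@@H](CCC(=O)O)C(=O)Nc1ccn([C@H]2O[C@@H](CO)[C@H](O)[C@H]2O)c(=O)n1` gives -0.28 in this assay

Compound 3 is the lowest of the three, and both steps away from it are beyond the scatter. Two single changes connect the measured compounds. The first is methylsulfanyl in place of carboxy on a saturated chain carbon, three bonds along the chain from an amide-type nitrogen and a carbonyl carbon; it gives a number 0.59 log units higher from compound 2 to compound 1 (beyond the scatter). The second is hydrogen in place of octyl on a saturated chain carbon, nine bonds along the chain from a carbonyl carbon; it gives a number 0.78 log units lower from compound 2 to compound 3 (beyond the scatter).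

Compound 4 `CCCCCCCCCC(=O)N[C@@H](CCSC)C(=O)Nc1ccn([C@H]2O[C@@H](CO)[C@H](O)[C@H]2O)c(=O)n1` has not yet been measured in this assay. It differs from compound 3 by methylsulfanyl in place of carboxy on a saturated chain carbon, three bonds along the chain from an amide-type nitrogen and a carbonyl carbon. Going by the values given here, this is the same change as the one from compound 2 to compound 1, at a place described word for word the same; the two cores differ by the second change above, which is the only difference between compound 3 and compound 4 on the one hand and compound 2 and compound 1 on the other. Among the compounds with values here, the expected step of a number 0.59 log units higher from compound 3 to compound 4 (beyond the scatter) is set close to the measured one, because a number 0.59 log units higher from compound 2 to compound 1 (beyond the scatter) is the only measured instance of this change and nothing suggests that the shorter acyl chain alters it. Compound 4 is therefore estimated at 0.31, with a likely range from -0.1 to 0.7.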

Compound 4, partition coefficient: 0.68
Beside the measured number, compound 4's estimate is 0.37 log units below it, within the range that was stated.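

In this assay methylsulfanyl in place of carboxy gives a number 0.59 log units higher from compound 2 to compound 1 (beyond the scatter) with the longer acyl chain and a number 0.96 log units higher from compound 3 to compound 4 (beyond the scatter) with the shorter one, so the direction of the change carries from one core to the other in this single pair of cores. Hydrogen in place of octyl gives a number 0.78 log units lower from compound 2 to compound 3 (beyond the scatter) with carboxy and a number 0.41 log units lower from compound 1 to compound 4 (beyond the scatter) with methylsulfanyl on the chain, so the printed sizes do not establish a fixed increment for either change, and two instances cannot show how the size would behave on any further core. No measurement at hand accounts for the difference in printed size between the two cores.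

The compounds shown leave open whether an amine or a hydroxy group in place of carboxy at this same place would move the number in the same direction. They also leave open how the methylsulfanyl step would read with an acyl chain longer than that of compound 1 or shorter than that of compound 4.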